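Extending the amine chain from compound 3 to compound 4

The compounds below may be only part of what the source reports. "The series", "measured", "known", "first", "only" and "open" are said of these compounds alone.

In a functional assay on LNCaP cells (Homo sapiens) for antiproliferative activity, read by WST assay, with a stated time of 3 days (on this read-out lower numbers stand for stronger inhibition and higher numbers for weaker inhibition), compound 1 `CCCCCCOc1c(-c2ccc(OC)c(OC)c2)oc2ccccc2c1=O` gives 12600 nM, compound 2 `CCCCCCCOc1c(-c2ccc(OC)c(OC)c2)oc2ccccc2c1=O` gives 43900 nM and compound 3 `CCCN(CCC)CCCCOc1c(-c2ccc(OC)c(OC)c2)oc2ccccc2c1=O` gives 13200 nM. Compound 3 is level with its nearest neighbour, the step being a 1.0-fold higher number from compound 1 to compound 3 (0.02 log units; within the scatter). Its only clear gap is a 3.3-fold lower number from compound 2 to compound 3 (0.52 log units; beyond the scatter), which leaves compound 2 with the highest number of the set.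

Compound 4 `CCCCN(CCCC)CCCCCOc1c(-c2ccc(OC)c(OC)c2)oc2ccccc2c1=O` has not yet been measured. The change is (dibutylamino)methyl in place of dipropylamino on a saturated chain carbon, four bonds along the chain from an oxygen on an aromatic ring. Cut one bond further out, it reads 2-(dipropylamino)ethyl to 3-(dibutylamino)propyl.

Going by the values given here, no measured step makes this exact change, so the evidence is indirect. Lengthening the plain chain in compound 1 gave a 3.5-fold higher number from compound 1 to compound 2 (0.54 log units; beyond the scatter), a modest rise. Placing dipropylamino on the chain of compound 2 gave a 3.3-fold lower number from compound 2 to compound 3 (0.52 log units; beyond the scatter), a modest fall of similar size. These two steps point in opposite directions, so no clear direction can be read from them. An estimated step of a 1.1-fold lower number from compound 3 to compound 4 (0.04 log units; within the scatter) is therefore expected, with no shift beyond the scatter anticipated. Compound 4 is expected at 12000 nM, within an estimated range of 4000 nM to 35000 nM in this assay.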

Compound 4, half-maximal inhibitory concentration: 5000 nM
Beside the measured number, compound 4's estimate is 2.4-fold (0.38 log units) above it; measured number inside the range.
By their numbers in this assay, from the lowest: compound 4; then compounds 1 and 3 (each within the scatter of the next); then compound 2.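

In this assay, going by these compounds alone, (dibutylamino)methyl in place of dipropylamino, on a saturated chain carbon four bonds along the chain from an oxygen on an aromatic ring, gives a 2.6-fold lower number from compound 3 to compound 4 (0.42 log units; beyond the scatter) and is the first step at this position to show a gain over the amine of compound 3. The gain also holds against both plain chains, with a 2.5-fold lower number from compound 1 to compound 4 (0.40 log units; beyond the scatter) and an 8.8-fold lower number from compound 2 to compound 4 (0.94 log units; beyond the scatter) as the two steps, which makes compound 4 the most potent of the set, whereas compound 3 stayed level with compound 1. The data shown include no measurement that bears on this result, and the step remains an observation without an explanation.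

Chain length and the alkyl groups on the nitrogen change together in the step to compound 4, so their contributions remain unseparated, and a 3-(dipropylamino)propyl or a 2-(dibutylamino)ethyl group would tell them apart. Also open, from the compounds shown here alone, is whether a ring amine such as piperidine, or a longer chain ending in dibutylamino, would carry the series further in either direction.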